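A few compounds are considered here, and "the series" means these few. Any claim that something is new, unique, unknown or untested is made for them only; others in the source may bear on it.

Compound 1, `COc1ccc(-c2cc(C3=Nc4c(C(C)(C)C)nn(CCCO)c4C(=O)NC3)ccc2OC)c(OC)c1`, gives 2 h in an ADME assay on microsomes from liver (Homo sapiens) for metabolic stability; a lower number here means that the compound disappears faster, a higher number that the compound lasts longer.
Compound 2, `COc1ccc(C2=Nc3c(C(C)(C)C)nn(CCCO)c3C(=O)NC2)cc1-c1ccccc1F`, gives 0.8 h in this assay.
Compound 3, `COc1ccc(-c2cc(C3=Nc4c(C(C)(C)C)nn(CCCO)c4C(=O)NC3)ccc2OC)cn1`, gives 2 h in this assay.

Compound 3 stands level with compound 1 at the digits shown, the two together holding the highest numbers of the three. Its nearest neighbour is compound 1, with no change at the digits printed from compound 1 to compound 3 (within the scatter); its furthest is compound 2, with a 2.5-fold higher number from compound 2 to compound 3 (0.40 log units; beyond the scatter).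

Compound 4, `COc1ccc(C2=Nc3c(C(C)(C)C)nn(CCCO)c3C(=O)NC2)cc1-c1ccc(C(=O)O)cc1`, differs from compound 3 in one place: 4-carboxyphenyl in place of 6-methoxypyridin-3-yl on an aromatic carbon. The three measured steps all concern the same position. Two of them, a 2.5-fold lower number from compound 1 to compound 2 (0.40 log units; beyond the scatter) and a 2.5-fold higher number from compound 2 to compound 3 (0.40 log units; beyond the scatter), were modest and beyond the scatter; the third, no change at the digits printed from compound 1 to compound 3 (within the scatter), stayed within it. Going by the values given here, none of them brings in a carboxyphenyl group, so no measured step bears directly on this change. On the record of that position, where the number moved only modestly in either direction, compound 4 is expected to stay near compound 3, with a step of a 1.3-fold higher number from compound 3 to compound 4 (0.10 log units; within the scatter) in this assay. The estimate for compound 4 is 2.5 h, with a range from 1 h to 6 h.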

Compound 4, half-life: 2 h
Beside the measured number, compound 4's estimate is 1.3-fold (0.10 log units) above it; low and high end bracket the measured number.
By their numbers in this assay, from the lowest: compound 2; then compounds 1, 3 and 4 (each within the scatter of the next).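

Compound 4 shows that at this aromatic carbon, ortho to a methoxy group, a 4-carboxyphenyl group, which brings in a hydrogen-bond donor that the 6-methoxypyridin-3-yl group lacks, leaves the half-life in this assay where it stood (no change at the digits printed from compound 3 to compound 4 (within the scatter); no change at the digits printed from compound 1 to compound 4 (within the scatter)). Going by these compounds alone, the earlier compounds offered only two groups that could not be told apart here, and this third, with a carboxyl group and a ring of carbon only, joins them. The 2-fluorophenyl group therefore stands apart from three groups rather than two, and the exchange for 4-carboxyphenyl reverses its loss (a 2.5-fold higher number from compound 2 to compound 4 (0.40 log units; beyond the scatter)), although the set remains too small to support a rule beyond these four compounds.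

The compounds shown leave open whether an amine, or a carboxylic acid held on a longer chain, would keep the half-life at this level in the same place. Nothing given here accounts for why the 2-fluorophenyl group differs from the other three groups or why the carboxyl group makes no difference.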